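This account rests on a few compounds, and the source may have more. Where it says the series, first, only, none or still open, it means among the compounds named here.

Measured in a physicochemical assay for solubility, in phosphate buffer, at pH 6.5; a higher number here means a more soluble compound, a lower number a less soluble compound:
- compound 1 `C=C[C@@H]1C[C@]1(NC(=O)[C@@H]1C[C@@H](Oc2nccc3cc(OC)ccc23)CN1C(=O)[C@@H](NC(=O)NC(C)(C)C)C(C)(C)C)C(=O)NS(=O)(=O)C1CC1`: 13 ug/mL
- compound 2 `C=C[C@@H]1C[C@]1(NC(=O)[C@@H]1C[C@@H](Oc2nccc3cc(OC)ccc23)CN1C(=O)[C@@H](NC(=O)N[C@H](COC)[C@@H](C)CC)C(C)(C)C)C(=O)NS(=O)(=O)C1CC1`: 326 ug/mL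
- compound 3 `C=C[C@@H]1C[C@]1(NC(=O)[C@@H]1C[C@@H](Oc2nccc3cc(OC)ccc23)CN1C(=O)[C@@H](NC(=O)N[C@H](COC)CC(C)C)C(C)(C)C)C(=O)NS(=O)(=O)C1CC1`: 225 ug/mL

Compound 3 lies within the scatter of compound 2 (a 1.4-fold lower number from compound 2 to compound 3 (0.16 log units; within the scatter)) and far from compound 1 (a 17-fold higher number from compound 1 to compound 3 (1.24 log units; beyond the scatter)).

Compound 4 `C=C[C@@H]1C[C@]1(NC(=O)[C@@H]1C[C@@H](Oc2nccc3cc(OC)ccc23)CN1C(=O)[C@@H](NC(=O)N[C@H](C(N)=O)C(C)(C)C)C(C)(C)C)C(=O)NS(=O)(=O)C1CC1` differs from compound 3 as follows: 1-carbamoyl-2,2-dimethylpropyl in place of 1-(methoxymethyl)-3-methylbutyl on an amide-type nitrogen.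

Two large steps bear on this position, a 25-fold higher number from compound 1 to compound 2 (1.40 log units; beyond the scatter) and a 17-fold higher number from compound 1 to compound 3 (1.24 log units; beyond the scatter), both replacing tert-butyl. Going by the values given here, no measured compound carries 1-carbamoyl-2,2-dimethylpropyl, so the direction is uncertain. A modest fall in this assay is expected, leaving compound 4 well short of the full drop back to compound 1 at 13 ug/mL.

The expected step is a 2.3-fold lower number from compound 3 to compound 4 (0.35 log units; beyond the scatter).

For compound 4 the estimated value is 100 ug/mL, with an expected range of 25 ug/mL to 350 ug/mL.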

Compound 4, solubility: 557 ug/mL
Compound 4: the middle estimate sits 5.6-fold (0.75 log units) below what was measured, outside the stated range (above it).
By their numbers in this assay, from the lowest: compound 1; then compounds 3, 2 and 4 (each within the scatter of the next, the first and the last beyond it).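

In this assay, 1-carbamoyl-2,2-dimethylpropyl on the amide-type nitrogen in place of tert-butyl gives a 43-fold higher number from compound 1 to compound 4 (1.63 log units; beyond the scatter), so at this position the large rise is not confined to chains carrying methoxymethyl. Against 1-(methoxymethyl)-3-methylbutyl the same group gives a 2.5-fold higher number from compound 3 to compound 4 (0.39 log units; beyond the scatter), while against 1-(methoxymethyl)-2-methylbutyl it gives a 1.7-fold higher number from compound 2 to compound 4 (0.23 log units; within the scatter). No measured evidence accounts for these steps. From the compounds shown here alone, it remains open whether an amine or a carboxylic acid in place of the carbamoyl group would keep the rise over tert-butyl, and how much depends on the 2,2-dimethylpropyl part.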